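A few compounds are considered here, and "the series" means these few. Any claim that something is new, unique, unknown or untested is made for them only; others in the source may bear on it.

Of the compounds shown here, three have numbers so far in a functional assay on A549 cells (Homo sapiens) for inhibition, read by colorimetric assay and MTT assay, with a stated time of 72 h; on this read-out lower numbers stand for stronger inhibition and higher numbers for weaker inhibition. Compound 1 `Cn1c2cnc1OCCCCCCCCCCOc1cc3ccccc3cc1-2` gives 20000 nM, compound 2 `C=CCCCCOc1cc(F)ccc1-c1cnc(OCCC=C)n1C` gives 74000 nM, and compound 3 `C#CCCCCOc1ncc(-c2ccccc2OC)n1C` gives 22000 nM. Compound 3 and compound 1 lie within the scatter of each other, so the two cannot be separated. Compound 2 reads a higher number than compound 3, and that gap lies beyond the scatter.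

Compound 4 `C=CCCCCOc1ncc(-c2ccccc2OC)n1C` differs from compound 3 at one place only: vinyl in place of ethynyl on a saturated chain carbon, four bonds along the chain from an oxygen on an aromatic ring. This puts vinyl in place of ethynyl on a saturated chain carbon, four bonds along the chain from an oxygen on an aromatic ring.

Within the data shown here, no measured pair isolates this change, so the evidence is indirect. Compound 2 also carries a chain ending in vinyl and stands at 74000 nM, but it differs from compound 3 in more than one place and gives only weak guidance. In this assay, little change is therefore expected, with any drift toward a higher number. The expected step is a 1.4-fold higher number from compound 3 to compound 4 (0.13 log units; within the scatter), which would stay within the scatter. For compound 4 the estimated value is 30000 nM, with an expected range from 14000 nM to 65000 nM.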

Compound 4, half-maximal inhibitory concentration: 5000 nM
Compound 4: the middle estimate sits 6.0-fold (0.78 log units) above what was measured, and the stated range ends above it.
By their numbers in this assay, from the lowest: compound 4; then compounds 1 and 3 (each within the scatter of the next); then compound 2.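

In this assay the end of this chain is not a silent position: vinyl in place of ethynyl, a double bond for a triple bond with the rest of the molecule unchanged, gives a 4.4-fold lower number from compound 3 to compound 4 (0.64 log units; beyond the scatter), a step beyond the scatter toward stronger inhibition. This is the first pair in the series that differs in one place only, so the read-out is shown to respond to the chain terminus alone, with no hydrogen-bond donor or acceptor entering or leaving and no ring involved. Nothing at hand accounts for the size or the direction of this step, which stands as an observation from a single pair.

The compounds shown leave open whether a fully saturated end at this place, such as an ethyl group, would continue the change or reverse it, and whether an amine or a longer chain there would be tolerated. They also leave open whether the same exchange of ethynyl for vinyl gives a step of similar size on a chain attached to a different core, such as one carrying a fluoro group on the aromatic ring.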